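Shortening the Anilino Chain: Expectation for Compound 4

This account rests on a few compounds, and the source may have more. Where it says the series, first, only, none or still open, it means among the compounds named here.

Three compounds share one core and differ only in the side chain attached through sulfur. Compound 1 `O=C(O)Cn1c(SCCCc2ccccc2)nc2ccccc21` gives 475 nM in an assay on HEK293 cells for displacement of a labelled ligand from prostaglandin D2 receptor 2 (Homo sapiens); on this read-out higher numbers stand for weaker inhibition and lower numbers for stronger inhibition. Compound 2 `O=C(O)Cn1c(SCCc2ccccc2)nc2ccccc21` gives 881 nM in this assay, and compound 3 `O=C(O)Cn1c(SCCCNc2ccccc2)nc2ccccc21` gives 2690 nM. Compound 3 therefore has the highest number of the three and is the weakest inhibitor among them: the step of a 3.1-fold higher number from compound 2 to compound 3 (0.48 log units; beyond the scatter) and the step of a 5.7-fold higher number from compound 1 to compound 3 (0.75 log units; beyond the scatter) both lie beyond the scatter.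

Compound 4 `O=C(O)Cn1c(SCCNc2ccccc2)nc2ccccc21` differs from compound 3 in one place: anilino in place of anilinomethyl on a saturated chain carbon, two bonds along the chain from a sulfur. The measured step that most resembles this change is the one where phenyl replaced benzyl on a saturated chain carbon, two bonds along the chain from a sulfur, which gave a 1.9-fold higher number from compound 1 to compound 2 (0.27 log units; within the scatter). Since that step stayed within the scatter, the expectation for this assay is a small rise in the number, or no change beyond the scatter. Compound 4 is thus estimated at 4000 nM, with a range from 1500 nM to 12000 nM. The expected step amounts to a 1.5-fold higher number from compound 3 to compound 4 (0.17 log units; within the scatter).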

Compound 4, half-maximal inhibitory concentration: 7690 nM
Compound 4: the middle estimate sits 1.9-fold (0.28 log units) below what was measured; the range from low to high includes it.
By their numbers in this assay, from the lowest: compounds 1 and 2 (each within the scatter of the next); then compound 3; then compound 4.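

Shortening the chain now registers clearly once a nitrogen stands in it, with a 2.9-fold higher number from compound 3 to compound 4 (0.46 log units; beyond the scatter), whereas the matching shortening without nitrogen gave a 1.9-fold higher number from compound 1 to compound 2 (0.27 log units; within the scatter). At the shorter length, anilino in place of phenyl gives an 8.7-fold higher number from compound 2 to compound 4 (0.94 log units; beyond the scatter), and the shortening and the nitrogen together give a 16-fold higher number from compound 1 to compound 4 (1.21 log units; beyond the scatter), which leaves compound 4 the weakest inhibitor of the four in this assay. The cost of the chain nitrogen is similar at both chain lengths: the same change on two cores in this assay, a 5.7-fold higher number (0.75 log units; beyond the scatter) from compound 1 to compound 3 and an 8.7-fold higher number (0.94 log units; beyond the scatter) from compound 2 to compound 4, 1.5-fold (0.19 log units) apart, within the scatter of two such steps.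

As far as these compounds go, it remains open whether this cost belongs to the nitrogen itself or to the hydrogen it carries, a question that an ether oxygen or a methylated nitrogen at the same place in the chain could address. From the compounds shown here alone, whether a longer chain than that of compound 3 would lower the number again is also open.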